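Methyl on the Ring Nitrogen: Does the Change Register?

The compounds below may be only part of what the source reports. "The series", "measured", "known", "first", "only" and "open" are said of these compounds alone.

Of the compounds shown here, three sharing a common core have been tested in a functional assay on PC-3 cells (Homo sapiens) for cytotoxicity, read by MTT assay, with a stated time of 72 h; a lower number here means a stronger inhibitor, a higher number a weaker inhibitor. Compound 1 `N=C(Nc1cccc(C(F)(F)F)c1)c1cc2c(-c3ccccc3)n[nH]c2cn1` gives 19900 nM. Compound 2 `Cn1nc(-c2ccccc2)c2cc(C(=N)Nc3cccc(C(F)(F)F)c3)ncc21`, in which the change methyl in place of hydrogen on an aromatic nitrogen has been made, gives 20900 nM, so that the step of a 1.1-fold higher number from compound 1 to compound 2 (0.02 log units; within the scatter) lies within the scatter of repeated measurements. Compound 3 `CN1CCN(c2ccc(NC(=N)c3cc4c(-c5ccccc5)n[nH]c4cn3)cc2)CC1` carries a different group on the amidine nitrogen and gives 17100 nM. Among the compounds with values here, the difference between the core of compound 1 and the core of compound 3 is not broken down here, and since no step between compound 1 and compound 3 is worked out, their two values can only be placed side by side: all three numbers fall within the usual scatter of one another, so no order among them can be read.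

Compound 4 `CN1CCN(c2ccc(NC(=N)c3cc4c(-c5ccccc5)nn(C)c4cn3)cc2)CC1` has not yet been measured in this assay. It differs from compound 3 by methyl in place of hydrogen on an aromatic nitrogen, and the surroundings of the change are described in the same words as for the pair of compound 1 and compound 2, so it is the same change made on a second pairing. The expectation rests on that single earlier case: because a 1.1-fold higher number from compound 1 to compound 2 (0.02 log units; within the scatter) stays within the scatter, the step from compound 3 to compound 4 is expected to be small as well. The expected step is a 1.1-fold higher number from compound 3 to compound 4 (0.03 log units; within the scatter). Compound 4 is expected to give 18500 nM in this assay. For compound 4 the expected range runs from 9000 nM to 38000 nM. One prior example is thin ground for a rule, and compound 4 will show whether the pattern holds.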

Compound 4, half-maximal inhibitory concentration: 5900 nM
Beside the measured number, compound 4's estimate is 3.1-fold (0.50 log units) above it; measured number outside the range, below it.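

In this assay, methyl in place of hydrogen on an aromatic nitrogen now gives a 2.9-fold lower number from compound 3 to compound 4 (0.46 log units; beyond the scatter), a modest step, while on the first pairing the same change gave a 1.1-fold higher number from compound 1 to compound 2 (0.02 log units; within the scatter). The change therefore does not carry over from one core to another with a single size, and the earlier small step was no safe guide to the later one: the same change on two cores in this assay, a 1.1-fold higher number (0.02 log units; within the scatter) from compound 1 to compound 2 and a 2.9-fold lower number (0.46 log units; beyond the scatter) from compound 3 to compound 4, 3.0-fold (0.48 log units) apart, beyond the scatter of two such steps. Within the data shown here, this does not show why the two cores respond differently, since the data give no reason for the gap, and with only two pairs it offers no rule for which way, or how far, the number would move on a third core.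

The compounds shown leave open whether an ethyl group or a longer chain on that same ring nitrogen would lower the number further, hold it level or raise it on the core of compound 3. They also leave open whether a third group on the amidine nitrogen, such as a simple phenyl or a chain ending in an amine, would respond to the methyl like compound 2 or like compound 4.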